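The source may hold more compounds than are shown below. What is called first, only, known or untested is meant among the compounds shown, and "the series" means these compounds.

Of the compounds shown here, three built on one shared core have been measured in an in vitro assay on Sf21 cells for inhibition of high affinity 3',5'-cyclic-AMP phosphodiesterase 7A (Homo sapiens), read by scintillation proximity assay, with a stated time of 30 min; on this read-out lower numbers stand for stronger inhibition and higher numbers for weaker inhibition. Compound 1 `O=C(NCc1ccncc1)c1ccc(NC(=O)c2cn(Cc3c(F)cccc3F)c3ccc(=O)[nH]c3c2=O)cc1` gives 20 nM, compound 2 `CSc1ccc(NC(=O)c2cn(Cc3c(F)cccc3F)c3ccc(=O)[nH]c3c2=O)cc1` gives 86 nM, and compound 3 `CN(C)c1ccc(NC(=O)c2cn(Cc3c(F)cccc3Cl)c3ccc(=O)[nH]c3c2=O)cc1` gives 39 nM. Compound 3 thus stands second highest of the three numbers: its gap to compound 1 lies within the scatter, while its gap to compound 2 reaches beyond it.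

Compound 4 `COc1ccc(NC(=O)c2cn(Cc3c(F)cccc3Cl)c3ccc(=O)[nH]c3c2=O)cc1Cl` has not yet been measured. It differs from compound 3 in one place: 3-chloro-4-methoxyphenyl in place of 4-(dimethylamino)phenyl on an amide-type nitrogen. Among the compounds with values here, only one measured step touches the same region, the aryl group on the amide nitrogen, and it is a 4.3-fold higher number from compound 1 to compound 2 (0.63 log units; beyond the scatter), a modest change in the direction of weaker inhibition. That step exchanged a long substituent for a short one, whereas the groups leaving and entering here share the same count of heavy atoms and the same count of donors and acceptors, so a step of at most that order, if any, is expected, more likely toward a higher number than a lower one. For compound 4 the estimate in this assay is 60 nM, with a range from 20 nM to 180 nM. That estimate corresponds to an expected step of a 1.5-fold higher number from compound 3 to compound 4 (0.19 log units; within the scatter).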

Compound 4, half-maximal inhibitory concentration: 34 nM
For compound 4 the middle estimate is 1.8-fold (0.25 log units) above the measured one, and the stated range covers the measured number.
By their numbers in this assay, from the lowest: compounds 1, 4 and 3 (each within the scatter of the next); then compound 2.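

In this assay, the exchange of 4-(dimethylamino)phenyl for 3-chloro-4-methoxyphenyl on the amide-type nitrogen comes to a 1.1-fold lower number from compound 3 to compound 4 (0.06 log units; within the scatter), so the two values cannot be told apart. Within the data shown here, the only earlier step in this region, a 4.3-fold higher number from compound 1 to compound 2 (0.63 log units; beyond the scatter), lay beyond the scatter, but it could not show whether the dimethylamino group of compound 3 was needed. Compound 4 settles that for this pair: it carries no dimethylamino group, yet gives 34 nM, and the result holds with a chlorine and a methoxy group on the ring and the same count of heavy atoms. No measurement shown offers an explanation for this result.

Because chlorine and methoxy enter together in place of dimethylamino, the compounds shown leave open what each contributes alone, as a phenyl group carrying only the methoxy or only the chlorine would show. Among these compounds, also open is how this aryl group responds to a carboxylic acid or a morpholine, and whether a longer chain ending in a pyridine, like the one in compound 1, would fit on the 3-chloro-4-methoxyphenyl group.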